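The source may hold more compounds than are shown below. What is called first, only, known or untested is meant among the compounds shown, and "the series" means these compounds.

Working notes on the series. In a physicochemical assay for solubility, using the shake flask method, in phosphate buffer, with a stated time of 24 h, at pH 6.8 (on this read-out lower numbers stand for lower solubility and higher numbers for higher solubility), compound 1 `COCCCN1C(/C=C/c2ccc(O)cc2)=CC(=O)CC1c1ccc(O)cc1` gives 38800 nM, compound 2 `COc1cc(/C=C/C(=O)/C=C(/C=C/c2ccc(O)c(OC)c2)NCCCO)ccc1O` gives 56300 nM, and compound 3 `COCCCNC(=C\C(=O)/C=C/c1ccc(O)cc1)/C=C/c1ccc(O)cc1` gives 14900 nM. On these three numbers compound 3 stands lowest; compound 1 is the nearest of the two others and compound 2 the furthest, and both separations lie beyond the scatter. Compound 4 `O=C(/C=C(/C=C/c1ccc(O)cc1)NCCO)/C=C/c1ccc(O)cc1` has not been measured in this assay. It differs from compound 3 in one place: hydroxy in place of methoxymethyl on a saturated chain carbon, two bonds along the chain from an amine nitrogen. For the measured compounds named here, no measured pair shows this change. Going by the values given here, the step of a 1.7-fold higher number from compound 3 to compound 4 (0.22 log units; within the scatter) is expected to be upward and modest, partly because compound 2, the only compound whose amine chain ends in hydroxy, gives 56300 nM. Compound 4 is therefore estimated at 25000 nM, within a range of 10000 nM to 60000 nM.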

Compound 4, solubility: 37900 nM
Estimate against measurement, compound 4: 1.5-fold (0.18 log units) below; measured number inside the range.
By their numbers in this assay, from the lowest: compound 3; then compounds 4, 1 and 2 (each within the scatter of the next).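

In this assay the change from (3-methoxypropyl)amino to (2-hydroxyethyl)amino now reads as a 2.5-fold higher number from compound 3 to compound 4 (0.41 log units; beyond the scatter) and gives the series its first measured pair that differs in one place. The read-out therefore responds to a change at this position on the chain, with the rest of the structure held constant.

This single pair alters chain length and end group together, and it leaves open how a 2-methoxyethyl chain or a chain ending in a carboxylic acid would read at this position. Nothing shown gives a measured reason for the step.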